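Hexyl Chain in Place of Chlorophenyl on the Di-N-oxide Core

The source may report more compounds than this note shows. Statements on the series, on what has been measured and on what is new or still open speak of the compounds shown alone.

Compound 1 `[O-][n+]1nc(NCOCc2ccc(Cl)cc2)[n+]([O-])c2ccccc21` gives 810 nM in a functional assay on SMMC-7721 cells (Homo sapiens) for cytotoxicity, read by MTT assay, with a stated time of 72 h (a higher number here means a weaker inhibitor, a lower number a stronger inhibitor), the lowest of the three numbers recorded. Compound 2 `CCCCOCNc1n[n+]([O-])c2ccccc2[n+]1[O-]` gives 3990 nM and compound 3 `CC(C)CCOCNc1n[n+]([O-])c2ccccc2[n+]1[O-]` gives 2860 nM. Compound 4 `CCCCCCCOCNc1n[n+]([O-])c2ccccc2[n+]1[O-]` differs from compound 1 as follows: hexyl in place of 4-chlorophenyl on a saturated chain carbon bound to an oxygen on a saturated carbon. The two measured steps that bear on this are the replacement of the same 4-chlorophenyl by a chain, a 4.9-fold higher number from compound 1 to compound 2 (0.69 log units; beyond the scatter) and a 3.5-fold higher number from compound 1 to compound 3 (0.55 log units; beyond the scatter), both modest weakenings beyond the scatter; between the two chains, a 1.4-fold lower number from compound 2 to compound 3 (0.14 log units; within the scatter) lies within the scatter. Compound 4 is therefore expected to weaken by a similar modest amount, a 3.5-fold higher number from compound 1 to compound 4 (0.54 log units; beyond the scatter). The estimate for compound 4 is 2800 nM, with a range from 1200 nM to 7000 nM.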

Compound 4, half-maximal inhibitory concentration: 3090 nM
Beside the measured number, compound 4's estimate is 1.1-fold (0.04 log units) below it; measured number inside the range.
By their numbers in this assay, from the lowest: compound 1; then compounds 3, 4 and 2 (each within the scatter of the next).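

In this assay, the hexyl chain at this saturated chain carbon does not match 4-chlorophenyl (a 3.8-fold higher number from compound 1 to compound 4 (0.58 log units; beyond the scatter)). Chain length and branching leave no mark across the three chains (compound 3 and compound 4: a 1.1-fold higher number from compound 3 to compound 4 (0.03 log units; within the scatter); compound 2 and compound 4: a 1.3-fold lower number from compound 2 to compound 4 (0.11 log units; within the scatter)), so the loss appears with removal of the 4-chlorophenyl rather than with the chain chosen. Nothing available explains this loss. Whether the ring or its chlorine matters remains open, since an unsubstituted phenyl or a cyclohexyl is not among these compounds. Going by these compounds, a longer chain also remains untested here.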